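The source may report more compounds than this note shows. Statements on the series, on what has been measured and on what is new or still open speak of the compounds shown alone.

Measured compounds in a functional assay on MDA-MB-231 cells (Homo sapiens) for antiproliferative activity, read by MTT assay, with a stated time of 24 h; on this read-out higher numbers stand for weaker inhibition and lower numbers for stronger inhibition:

Compound 1 `COc1ccc(C(=O)/C=C/c2cc(-c3cc(OC)c(OC)c(OC)c3)n3nc(-c4ccccc4)cc3n2)cc1OC` gives 18300 nM.
Compound 2 `COc1cc(-c2cc(/C=C/C(=O)c3ccc(C)c(C)c3)nc3cc(-c4ccccc4)nn23)cc(OC)c1OC` gives 13500 nM.
Compound 3 `COc1ccc(-c2cc(/C=C/C(=O)c3ccccc3)nc3cc(-c4ccccc4)nn23)cc1` gives 9900 nM.

All three numbers sit close together. Compound 2 stands with compound 1 as its nearest neighbour, a 1.4-fold lower number from compound 1 to compound 2 (0.13 log units; within the scatter), and the gap from compound 2 to compound 3 is of the same small size, so on the numbers shown compound 2 is not separated from either of the other two.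

Compound 4 `COc1cc(-c2cc(C(=O)/C=C/c3ccc(C)cc3)nc3cc(-c4ccccc4)nn23)cc(OC)c1OC` is the next compound in the series. Its difference from compound 2 is (2-(4-methylphenyl)ethenyl)carbonyl in place of 2-((3,4-dimethylphenyl)carbonyl)ethenyl on an aromatic carbon. Among the measured compounds shown here, the only measured step at a related position, the one from compound 1 to compound 2 where the aryl on the carbonyl carbon was altered, stayed within the scatter. For the measured compounds named here, no measured pair shows the enone turned round, so that part of the change has no precedent here. Given that every change so far has left the numbers where they were, the expectation for compound 4 is a step of a 1.1-fold lower number from compound 2 to compound 4 (0.05 log units; within the scatter), that is, none beyond the scatter. Compound 4 is thus estimated at 12000 nM, with a range from 5500 nM to 26000 nM.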

Compound 4, half-maximal inhibitory concentration: 18600 nM
The estimate for compound 4 lay 1.6-fold (0.19 log units) below the measured number; low and high end bracket the measured number.
By their numbers in this assay, from the lowest: compounds 3, 2, 1 and 4 (each within the scatter of the next).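

In this assay, among the compounds shown here, reversing the enone on the same aromatic carbon, with 2-((3,4-dimethylphenyl)carbonyl)ethenyl replaced by (2-(4-methylphenyl)ethenyl)carbonyl, gives a 1.4-fold higher number from compound 2 to compound 4 (0.14 log units; within the scatter) and is the first measured step at this attachment point in which the carbonyl sits directly on the core. This position therefore tolerates either enone direction on the numbers shown, although the pair changes the direction and the aryl end together and cannot separate their contributions. No other data bear on this result.

Still open, as far as these compounds go, is whether any change at this position moves the number beyond the scatter, since every step read so far stays within it. A morpholine or carboxylic acid on the terminal phenyl, or a longer chain in place of the ethenyl linker, would test this position with groups unlike the methyl and methoxy substituents shown.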